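The compounds below may be only part of what the source reports. "The series", "measured", "known", "first", "only" and "open" are said of these compounds alone.

Compound 1 `CCOC(=O)CCCCCOc1cccc(CN(C(=O)c2ccc(-c3cccc(C(C)=O)c3)cc2)C(C)C)c1`: in an ADME assay on HEK293 cells (Homo sapiens) for cytotoxicity, read by CellTiter-Glo and resazurin assay, with a stated time of 72 h (on this read-out higher numbers stand for an effect only at larger amounts of compound and lower numbers for an effect already at smaller amounts), compound 1 gives only the limit > 26000 nM.
Compound 2 `CCOC(=O)CCCCCOc1cccc(CN(C(=O)c2ccc(-c3ccc4c(c3)OCCO4)cc2)C(C)C)c1`: in this assay compound 2 gives only the limit > 24400 nM.

Both values are limits of the assay and not numbers, so compound 2 stands at the limit alongside compound 1 (the limit of > 24400 nM in this assay, at which 1 of the 2 values shown sits, (the limit of > 26000 nM in this assay, at which 1 of the 2 values shown sits)). Among the compounds with values here, the single measured step, a step that the two limits leave unreadable from compound 1 to compound 2, cannot be read. Compound 3 `CCOC(=O)CCCCCOc1cccc(CN(C(=O)c2ccc(-c3cc(F)cc(OC)c3)cc2)C(C)C)c1` carries 3-fluoro-5-methoxyphenyl in place of 2,3-dihydro-1,4-benzodioxin-6-yl on an aromatic carbon. Within the data shown here, no measured step bears readably on this change; with both values at the limit, no shift beyond the scatter is expected, and the expected step that the limit leaves unreadable from compound 2 to compound 3 leaves compound 3 at the limit. Compound 3 is estimated at 30000 nM, range 15000 nM to 60000 nM.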

Compound 3, half-maximal effective concentration: > 26000 nM
Compound 3: only a limit was reported; the forecaster's own chance of this, stated with the estimate: 85%; the middle value is on the limit's open side.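

Within the data shown here, compound 1, compound 2 and compound 3 all give only limits in this assay, so no step among them can be read. From the compounds shown here alone, whether the group at this place changes the read-out at all remains open.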